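This account rests on a few compounds, and the source may have more. Where it says the series, first, only, none or still open, it means among the compounds named here.

Compound 1 `CCOC(=O)C1=Cc2ccccc2OC1(OCc1cn(CC(=O)Nc2ccc(C)cc2)nn1)C(F)(F)F` is one of three compounds tested in a functional assay on DU-145 cells (Homo sapiens) for inhibition, read by MTT assay, with a stated time of 24 h; on this read-out higher numbers stand for weaker inhibition and lower numbers for stronger inhibition. For compound 1 the assay reports only a limit, > 150000 nM, and not a number. Compound 2 `CCOC(=O)C1=Cc2ccccc2OC1(OCc1cc(-c2ccc(Br)cc2)no1)C(F)(F)F` gives 71700 nM, while compound 3 `CCOC(=O)C1=Cc2ccccc2OC1(OCc1cc(-c2ccc(Cl)cc2)no1)C(F)(F)F` gives 18200 nM; the step of a 3.9-fold lower number from compound 2 to compound 3 (0.60 log units; beyond the scatter) concerns chloro in place of bromo on an aromatic carbon and does not bear on the change considered here. Compound 4 `CCOC(=O)C1=Cc2ccccc2OC1(OCc1cn(CC(=O)NC2CCCCC2)nn1)C(F)(F)F` differs from compound 1 by cyclohexyl in place of 4-methylphenyl on an amide-type nitrogen. Going by the values given here, no measured step covers this change, and compound 1 sits at the limit of > 150000 nM in this assay, at which 1 of the 3 values shown sits, so nothing in the data points to a gain. Compound 4 is therefore expected at about 150000 nM, in a range from 50000 nM to 450000 nM. The expected step is a number no higher from compound 1 to compound 4 (the limit leaves the size open), within the scatter.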

Compound 4, half-maximal inhibitory concentration: 10200 nM
Estimate against measurement, compound 4: 15-fold (1.17 log units) above, and the stated range ends above it.
By their numbers in this assay, from the lowest: compounds 4 and 3 (each within the scatter of the next); then compound 2. At a limit, above all of these: compound 1.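

Cyclohexyl in place of 4-methylphenyl on an amide-type nitrogen gives an at least 14-fold lower number from compound 1 to compound 4 (1.16 log units; beyond the scatter), so in this assay the group at this position can decide whether the compound gives a measurable number at all. The earlier compounds shown here held no pair that differed at this position. The size of the step remains a floor, as compound 1 stands at a limit and not at a number: the limit of > 150000 nM in this assay, at which 1 of the 4 values shown sits.

The compounds shown leave open whether a cyclopentyl group, an open hexyl chain or a piperidine ring carrying a basic amine would hold the lower number. They also leave open whether the same change would give a similar step on another core.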